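The source may report more compounds than this note shows. Statements on the series, on what has been measured and on what is new or still open speak of the compounds shown alone.

Of the compounds shown here, two have so far been measured in an assay on HEK293 cells for displacement of a labelled ligand from growth hormone secretagogue receptor type 1 (Homo sapiens), with a stated time of 60 min; a lower number here means a stronger inhibitor, a higher number a weaker inhibitor. Compound 1 `Cc1ccccc1-c1nc2cn(-c3cccc(C#N)c3)nc2c(=O)n1CC1CCCN(C(C)C)C1` gives 32 nM in this assay. Compound 2 `COc1cccc(-n2cc3nc(-c4cccnc4C)n(C[C@H]4CCCN(CC5CCC5)C4)c(=O)c3n2)c1` gives 1.6 nM in this assay, the lower of the two numbers; the gap to compound 1 lies beyond the usual scatter of repeated measurements. Among the measured compounds shown here, the two measured compounds differ in several places at once, so no single step between measured compounds has been recorded, and nothing in these numbers isolates the contribution of any one group.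

Compound 3 `COC[C@H](C)N1CCC[C@H](Cn2c(-c3cccnc3C)nc3cn(-c4cccc(OC)c4)nc3c2=O)C1` has not yet been measured. It differs from compound 2 in one place only: 1-(methoxymethyl)ethyl in place of cyclobutylmethyl on an amine nitrogen in a ring. Everything else in the molecule is kept as in compound 2.

For the measured compounds named here, since no measured pair shows how a change at this amine nitrogen moves the number, the expectation rests on compound 2 alone. The step from compound 2 to compound 3 is expected to be small, a 1.9-fold higher number from compound 2 to compound 3 (0.27 log units; within the scatter), perhaps toward a slightly higher number but not clearly beyond the scatter. Compound 3 is therefore expected to give about 3 nM in this assay, with a likely range from 1 nM to 10 nM.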

Compound 3, half-maximal inhibitory concentration: 1.7 nM
Compound 3: middle estimate off by 1.8-fold (0.25 log units), on the high side; the range from low to high includes it.
By their numbers in this assay, from the lowest: compounds 2 and 3 (each within the scatter of the next); then compound 1.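

In this assay, among the compounds shown here, 1-(methoxymethyl)ethyl in place of cyclobutylmethyl on an amine nitrogen in a ring gives a 1.1-fold higher number from compound 2 to compound 3 (0.03 log units; within the scatter) and is the first single change recorded at this position. With the rest of compound 2 kept, the four-membered non-aromatic ring of carbon can give way to a group with no ring, an ether oxygen and a defined stereocentre without the number moving beyond the scatter, which the earlier pair, differing in several places at once, could not show. No measurement offered here explains why these two groups read alike within the scatter.

As far as these compounds go, it remains open whether this position would accept groups of a different kind as readily, such as a hydroxyl, a carboxylic acid, a primary amine or a longer chain on the same nitrogen. Also open, from the compounds shown here alone, is whether the opposite configuration at the stereocentre of the 1-(methoxymethyl)ethyl group would leave the number within the scatter, and whether the same exchange would behave alike with other groups elsewhere on the shared core.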